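Dithiocarbamate series: removing the carbamate from compound 3

The compounds below may be only part of what the source reports. "The series", "measured", "known", "first", "only" and "open" are said of these compounds alone.

The series shares a triazolylmethyl dithiocarbamate on a piperazine and is followed in a functional assay on ECa-109 cells (Homo sapiens) for inhibition, read by MTT assay, with a stated time of 72 h; on this read-out lower numbers stand for stronger inhibition and higher numbers for weaker inhibition. Compound 1 `COc1ccc(Cn2cc(CSC(=S)N3CCN(C(=O)OCc4ccccc4)CC3)nn2)cc1` gives 58300 nM and compound 2 `O=C(OCc1ccccc1)N1CCN(C(=S)SCc2cn(Cc3ccccc3F)nn2)CC1` gives 27000 nM. Compound 3 `COc1cc(Cn2cc(CSC(=S)N3CCN(C(=O)OCc4ccccc4)CC3)nn2)cc(OC)c1OC` is reported only as a limit, > 128000 nM, so compound 3 sits at the weak end of the numbers shown; the only evidence on it is the limit of > 128000 nM in this assay, at which 1 of the 3 values shown sits. The measured steps all concern the aryl group on the saturated chain carbon bound to the aromatic nitrogen: a 2.2-fold lower number from compound 1 to compound 2 (0.33 log units; beyond the scatter), an at least 2.1-fold higher number from compound 1 to compound 3 (0.34 log units; beyond the scatter) and an at least 4.7-fold higher number from compound 2 to compound 3 (0.67 log units; beyond the scatter).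

Compound 4 `COc1cc(Cn2cc(CSC(=S)N3CCNCC3)nn2)cc(OC)c1OC` differs from compound 3 elsewhere, at the piperazine: hydrogen in place of benzyloxycarbonyl on an amine nitrogen in a ring. Within the data shown here, none of the measured steps touches this position, so no step bears directly on the change, and the only anchor is the limit of compound 3. With the starting point already beyond the measurable range, the expectation is that compound 4 most likely again returns a limit rather than a number, with a wide range either way. Compound 4 is therefore estimated at 150000 nM, between 40000 nM and 500000 nM. The expected step in this assay is a step that the limit leaves unreadable from compound 3 to compound 4, which is not beyond the scatter.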

Compound 4, half-maximal inhibitory concentration: > 128000 nM
Compound 4 ended at the assay's limit (the forecaster's own chance of this, stated with the estimate: 65%); the middle value does not contradict the limit.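

Compound 3 and compound 4 both end at a limit, so no step can be read between them: the limit of > 128000 nM in this assay, at which 2 of the 4 values shown sit.

The compounds shown leave open whether hydrogen in place of benzyloxycarbonyl on the amine nitrogen in the ring changes inhibition at all, and in which direction.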